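The source may report more compounds than this note shows. Statements on the series, on what has been measured and on what is new or still open speak of the compounds shown alone.

Measured compounds:

- compound 1, `CC(C)Nc1cc(Oc2ccc(NC(=O)Nc3cccc(C(F)(F)F)c3)cc2)ncn1`, gives 40 nM in an assay on isolated protein for inhibition of serine/threonine-protein kinase TNNI3K (Homo sapiens); on this read-out higher numbers stand for weaker inhibition and lower numbers for stronger inhibition
- compound 2, `CNc1cc(Oc2ccc(NC(=O)Nc3cccc(C(C)F)c3)cc2)ncn1`, gives 79 nM in this assay
- compound 3, `CNc1cc(Oc2c(C)cc(NC(=O)Nc3cccc(C(F)(F)F)c3)cc2Cl)ncn1`, gives 79 nM in this assay

All three share the same diaryl urea core joined through an ether to an aminopyrimidine. Compound 1 shows the lowest of the three numbers, but its nearest neighbour, compound 2, and its furthest, compound 3, both sit at a distance that lies within the usual scatter of this measurement, so none of the three can be called stronger or weaker than the others. For the measured compounds named here, no two of the measured compounds differ from each other in a single place, so no isolated step has been observed yet.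

Compound 4, `O=C(Nc1ccc(Oc2cc(NCCO)ncn2)cc1)Nc1cccc(C(F)(F)F)c1`, is the next compound to be tested. It differs from compound 1 in one place only: 2-hydroxyethyl in place of isopropyl on a nitrogen on an aromatic ring. Because compound 1 gives 40 nM and the change from isopropylamino to (2-hydroxyethyl)amino keeps the size of the group the same, the step from compound 1 to compound 4 is expected to be small, at most a mild move toward a higher number, and quite possibly none beyond the scatter. Compound 4 is therefore estimated at 60 nM, in a range from 20 nM to 200 nM, which corresponds to an expected step of a 1.5-fold higher number from compound 1 to compound 4 (0.18 log units; within the scatter).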

Compound 4, half-maximal inhibitory concentration: 32 nM
Beside the measured number, compound 4's estimate is 1.9-fold (0.27 log units) above it; the measured number falls inside the stated range.
By their numbers in this assay, from the lowest: compounds 4, 1, 2 and 3 (each within the scatter of the next, the first and the last beyond it).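

In this assay, replacing isopropyl with 2-hydroxyethyl on the nitrogen gives a 1.3-fold lower number from compound 1 to compound 4 (0.10 log units; within the scatter), so the two compounds cannot be told apart. For the compounds shown here, this is the first change seen in isolation, and it shows that this nitrogen can carry a group with 1 hydrogen-bond donor and 1 hydrogen-bond acceptor, where isopropyl has neither, with no change in the number beyond the scatter; both groups have 3 heavy atoms, so the step says nothing about a change in size. No measurement is available that would explain this result.

This is still one step at one position, and it leaves open whether the number would hold with a longer chain such as 3-hydroxypropyl, with an amine such as 2-aminoethyl, or with a carboxylic acid such as carboxymethyl on the same nitrogen. It also leaves open whether 2-hydroxyethyl would behave the same way on a shared core bearing different substituents on its other rings.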